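Defining the stereocentre on the amino-hydroxy chain

This account rests on a few compounds, and the source may have more. Where it says the series, first, only, none or still open, it means among the compounds named here.

Compound 2 `CC(C)c1n[nH]c2c(NCc3ccc(-c4ccccn4)cc3)nc(SCCC(N)=O)nc12` gives 120 nM in a functional assay on HT cells (Homo sapiens) for antiproliferative activity, read by fluorescence, with a stated time of 72 h (on this read-out lower numbers stand for stronger inhibition of growth and higher numbers for weaker inhibition of growth), the highest number of the two measured; its nearest neighbour, compound 1 `CC(C)c1n[nH]c2c(NCc3ccc(-c4ccccn4)cc3)nc(SCC(O)CN)nc12`, gives 55 nM. Compound 3 `CC(C)c1n[nH]c2c(NCc3ccc(-c4ccccn4)cc3)nc(SC[C@H](O)CN)nc12` differs from compound 2 by 2-amino-1-hydroxyethyl in place of carbamoylmethyl on a saturated chain carbon bound to a sulfur. Among the measured compounds shown here, the only step that bears on this is the reverse of it, a 2.2-fold higher number from compound 1 to compound 2 (0.34 log units; beyond the scatter), so a step of similar size back down is expected. Compound 3 is therefore estimated at 50 nM with a range from 25 nM to 110 nM, a step of a 2.4-fold lower number from compound 2 to compound 3 (0.38 log units; beyond the scatter) expected beyond the scatter.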

Compound 3, concentration for 50% growth inhibition: 63 nM
For compound 3 the middle estimate is 1.3-fold (0.10 log units) below the measured one; the measured number falls inside the stated range.
By their numbers in this assay, from the lowest: compounds 1, 3 and 2 (each within the scatter of the next, the first and the last beyond it).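

In this assay, drawing the stereocentre as R leaves the number within the scatter of the undefined form (a 1.1-fold higher number from compound 1 to compound 3 (0.06 log units; within the scatter)). The 2-amino-1-hydroxyethyl chain with this configuration also lies within the scatter of carbamoylmethyl (a 1.9-fold lower number from compound 2 to compound 3 (0.28 log units; within the scatter)), although the undefined form lay beyond it. This reading of the position rests on one point: the fact that one of compounds 1 and 3 is drawn with a defined configuration and the other without, at the place where they differ.

The compounds shown leave open how the S configuration would read. They also leave open how a carboxylic acid or a simple amine on this sulfur-bound chain would compare.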